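This account rests on a few compounds, and the source may have more. Where it says the series, first, only, none or still open, it means among the compounds named here.

Three compounds share a core carrying three methoxy groups on an aromatic ring, joined through a nitrogen to a benzyl group, and they were tested in a functional assay on KYSE-450 cells (Homo sapiens) for inhibition, read by MTT assay, with a stated time of 48 h; on this read-out higher numbers stand for weaker inhibition and lower numbers for stronger inhibition. Compound 1 `C/C=C/C(=O)N(Cc1cccc(O)c1)c1cc(OC)c(OC)c(OC)c1` gives 14700 nM in this assay. Compound 2 `COc1ccc(CN(C(=O)C2CC2)c2cc(OC)c(OC)c(OC)c2)cc1O`, whose nitrogen carries a cyclopropyl amide, gives 80 nM, the lowest of the three numbers and therefore the strongest inhibition in this set. Compound 3 `COC(=O)c1cc(CNc2cc(OC)c(OC)c(OC)c2)ccc1OC`, which has no amide on its nitrogen at all, gives 41100 nM; its number and that of compound 1 both lie far beyond the usual scatter from compound 2.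

The step of interest leads from compound 2 to compound 4 `COc1ccc(CN(C(=O)C[Se]C#N)c2cc(OC)c(OC)c(OC)c2)cc1O`, which is not yet measured. The change is a group of 4 heavy atoms (2 carbon, 1 nitrogen, 1 selenium; no ring) in place of a group of 3 heavy atoms (3 carbon; one three-membered non-aromatic ring of carbon only), on a carbonyl carbon. For the measured compounds named here, no comparable change between two measured compounds is available here, so there is no measured step to lean on.

Both compounds keep the amide, which the measured set suggests matters because of the gap between 80 nM for compound 2 and 41100 nM for compound 3. The expectation is a small step, close to the scatter and if anything toward weaker inhibition, shown as a 1.9-fold higher number from compound 2 to compound 4 (0.27 log units; within the scatter). For compound 4 the estimated value in this assay is 150 nM, between 30 nM and 800 nM.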

Compound 4, half-maximal inhibitory concentration: 280 nM
Estimate against measurement, compound 4: 1.9-fold (0.27 log units) below, within the range that was stated.
By their numbers in this assay, from the lowest: compound 2; then compound 4; then compound 1; then compound 3.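

In this assay, exchanging the cyclopropyl on this carbonyl carbon for an open-chain group holding selenium and a nitrile gives a 3.5-fold higher number from compound 2 to compound 4 (0.54 log units; beyond the scatter), a modest loss of inhibition that still lies beyond the usual scatter. The earlier compounds shown here differ from one another in more than one place, so they could not isolate this position; this pair differs only in the group on the carbonyl carbon, and it shows that the three-membered ring can be replaced by a chain without inhibition collapsing. Nothing measured in this set speaks to the reason for the step.

As far as these compounds go, a single pair cannot separate the contribution of selenium from that of the nitrile or from the loss of the ring, so it remains open how a simple ethyl group, or the same chain with sulfur in place of selenium, would compare. From the compounds shown here alone, it also remains open whether a larger ring such as cyclobutyl on the same carbonyl carbon would keep, improve or reduce the inhibition seen with compound 2.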